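This account rests on a few compounds, and the source may have more. Where it says the series, first, only, none or still open, it means among the compounds named here.

Compound 1 `COc1cc(Cl)cc(-c2nn(-c3cccc(NC(=O)Nc4ccc(Cl)c(C(F)(F)F)c4)c3)cc2-c2ccncc2)c1` and compound 2 `COc1cc(Cl)cc(-c2nn(-c3cccc(NC(=O)Nc4cccc(C(F)(F)F)c4)c3)cc2-c2ccncc2)c1` share one core and differ at a single aromatic carbon. In a functional assay on SK-MEL-28 cells (Homo sapiens) for inhibition, read by sulforhodamine B assay, with a stated time of 48 h, tested at 0.1 uM (on this read-out higher numbers stand for a weaker effect at the one concentration tested and lower numbers for a stronger effect), compound 1 gives 106%, while compound 2 gives 100%; the step of a number 6 percentage points lower from compound 1 to compound 2 (within the scatter) is too small to count. Of the two numbers, that of compound 2 is the lower, but its gap to compound 1 lies within the scatter. Compound 3 `COc1cc(Cl)cc(-c2nn(-c3cccc(NC(=O)c4cccc(C(F)(F)F)c4)c3)cc2-c2ccncc2)c1` differs from compound 2 by 3-(trifluoromethyl)phenyl in place of (3-(trifluoromethyl)phenyl)amino on a carbonyl carbon. Within the data shown here, the one measured step concerns a different change, so nothing here bears on this one, and no shift beyond the scatter is expected. Compound 3 is estimated at 100%, between 85% and 115%. The expected step is no change at the digits printed from compound 2 to compound 3 (within the scatter).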

Compound 3, a percentage reported as activity, at one concentration (the size of the read-out at that concentration, not a potency): 97%
The estimate for compound 3 lay 3 percentage points above the measured number, and the stated range covers the measured number.
By their numbers in this assay, from the lowest: compounds 3, 2 and 1 (each within the scatter of the next).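

In this assay, putting 3-(trifluoromethyl)phenyl in place of (3-(trifluoromethyl)phenyl)amino on the carbonyl carbon gives a number 3 percentage points lower from compound 2 to compound 3 (within the scatter), so losing the amino nitrogen and its hydrogen-bond donor leaves the read-out unchanged at this one concentration. The wider replacement, which also loses the chloro group, gives a number 9 percentage points lower from compound 1 to compound 3 (within the scatter) and likewise counts as no change. Nothing available explains why this position shows no response. Open, from the compounds shown here alone, is whether a carboxylic acid or a longer chain on this carbonyl carbon would move the number beyond the scatter.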